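Moving the Fluorine on the Sulfonyl Aryl Ring

The compounds below may be only part of what the source reports. "The series", "measured", "known", "first", "only" and "open" are said of these compounds alone.

Three compounds sharing a benzylic sulfonamide linked to an amide have been tested in an assay on cells for inhibition of C-X-C chemokine receptor type 4 (Homo sapiens), with a stated time of 22 h, tested at 100 nM; on this read-out lower numbers stand for less inhibition and higher numbers for more inhibition at the one concentration tested (going by the name of the read-out). Compound 1 `O=C(NCc1ccc(CNS(=O)(=O)c2cccc(F)c2)cc1)c1cc2ccccn2n1` gives 40% in this assay. Compound 2 `O=C(NCc1ccc(CNS(=O)(=O)c2ccc(F)cc2F)cc1)c1cncnc1` gives 74%, and compound 3 `Cn1nccc1C(=O)NCc1ccc(CNS(=O)(=O)c2ccc3c(c2)CCO3)cc1` gives 40%. On these numbers compound 1 stands level with compound 3 at the digits printed, the two together forming the lowest pair of the three, while compound 2 lies a clear distance higher, beyond the usual scatter. Going by the values given here, no pair among the measured compounds differs in one place only, so no single step can be read from them.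

Compound 4 `O=C(NCc1ccc(CNS(=O)(=O)c2ccccc2F)cc1)c1cc2ccccn2n1` is the next compound considered. It differs from compound 1 only in the sulfonyl aryl group: 2-fluorophenyl in place of 3-fluorophenyl on a sulfonyl sulfur. The structures of compound 1 and compound 4 hold the same atoms, joined differently. Among the compounds with values here, with no measured step to guide the change, the move from compound 1 to compound 4 is expected to bring little change, a number 5 percentage points higher from compound 1 to compound 4 (within the scatter), within the scatter. Compound 4 is therefore estimated to give 45% in this assay, within a range from 25% to 65%.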

Compound 4, a percentage reported as inhibition, at one concentration (the size of the read-out at that concentration, not a potency): 40%
Compound 4: the middle estimate sits 5 percentage points above what was measured, within the range that was stated.
By their numbers in this assay, from the lowest: compounds 1, 3 and 4 (each within the scatter of the next); then compound 2.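

In this assay, going by these compounds alone, placing 2-fluorophenyl in place of 3-fluorophenyl on a sulfonyl sulfur gives no change at the digits printed from compound 1 to compound 4 (within the scatter), the first single change that can be read in this set. It shows that, on the core of compound 1, these two fluorophenyl groups cannot be told apart on this read-out at the one concentration tested. No other measurement bears on this result, so it offers no account of why the two groups read alike.

On these data alone, it remains open whether a plain phenyl, or a chlorine or a methoxy group in place of the fluorine, would read the same on this core. Within the data shown here, also open is whether the same exchange of fluorophenyl groups would read alike with a different amide partner, such as the one in compound 2.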